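The compounds below may be only part of what the source reports. "The series", "measured", "known", "first", "only" and "open" are said of these compounds alone.

Compound 1 `COc1ccc(CSc2nnc(-c3cc(OC)c(OC)c(OC)c3)n2-c2ccc(OC)cc2)cc1`: > 60000 nM, a limit
Compound 2 `COc1cc(-c2nnc(S)n2-c2ccc(N(C)C)cc2)cc(OC)c1OC`: > 60000 nM, a limit
Compound 3 `COc1ccc(CSc2nnc(-c3cc(OC)c(OC)c(OC)c3)n2-c2ccc(N(C)C)cc2)cc1`: > 60000 nM, a limit

In a functional assay on HT-29 cells (Homo sapiens) for inhibition, read by MTT assay, with a stated time of 48 h (a higher number here means a weaker inhibitor, a lower number a stronger inhibitor), compound 3 gives only a limit, > 60000 nM. The other two compounds share this position: the limit of > 60000 nM in this assay, at which 3 of the 3 values shown sit.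

Compound 4 `COc1cc(-c2nnc(SCC(=O)c3ccc(F)cc3)n2-c2ccc(N(C)C)cc2)cc(OC)c1OC` alters the group on sulfur: (4-fluorophenyl)carbonyl in place of 4-methoxyphenyl on a saturated chain carbon bound to a sulfur. The closest measured change is a step that the two limits leave unreadable from compound 2 to compound 3, which also concerns the sulfur. The other measured change, a step that the two limits leave unreadable from compound 1 to compound 3, concerns an aromatic carbon. Neither gives a size that can be carried over, so any expectation here is loose.

A small shift toward stronger inhibition is expected, shown as the estimated at least 1.2-fold lower number from compound 3 to compound 4 (0.07 log units; that floor lies within the scatter), and another limit is quite possible. For compound 4 the estimated value is 50000 nM, with an expected range of 5000 nM to 100000 nM.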

Compound 4, half-maximal inhibitory concentration: 78100 nM
Compound 4: the middle estimate sits 1.6-fold (0.19 log units) below what was measured, and the stated range covers the measured number.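

The steps from compound 2 and from compound 3 to compound 4 cannot be read: those two compounds give only limits. The compounds shown leave open whether changing the group on sulfur shifts the number in this assay at all.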